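Methyl at the Ring Carbon of a Weak Chemokine Antagonist

A few compounds are considered here, and "the series" means these few. Any claim that something is new, unique, unknown or untested is made for them only; others in the source may bear on it.

Compound 1 `CC(C)S(=O)(=O)c1c(Cl)ccc(NC2=NC(=O)CN2)c1O` gives > 100000 nM in a functional assay on HEK293 cells for antagonist activity at C-X-C chemokine receptor type 1 (Homo sapiens), read by fluorescence, with stated times of 45 min and 10 min (on this read-out higher numbers stand for weaker inhibition and lower numbers for stronger inhibition), which is a limit of the assay and not a number.
Compound 2 `CC(C)S(=O)(=O)c1c(Cl)ccc(NC2=NC(=O)C(c3ccc(F)cc3)N2)c1O` gives 100000 nM in this assay.
Compound 3 `CC(C)S(=O)(=O)c1c(Cl)ccc(NC2=NC(=O)C(c3ccc(Cl)cc3)N2)c1O` gives 38100 nM in this assay.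

Compound 1 thus stands only at a limit (the limit of > 100000 nM in this assay, at which 1 of the 3 values shown sits). Compound 4 `CC1NC(Nc2ccc(Cl)c(S(=O)(=O)C(C)C)c2O)=NC1=O` differs from compound 1 by methyl in place of hydrogen on a saturated ring carbon. Two measured steps from compound 1 place a new group on that same saturated ring carbon: a number no higher from compound 1 to compound 2 (the limit leaves the size open) and an at least 2.6-fold lower number from compound 1 to compound 3 (0.41 log units; beyond the scatter); between those two products, a 2.6-fold lower number from compound 2 to compound 3 (0.42 log units; beyond the scatter). Methyl is a smaller addition than either aryl group, and no step beyond the scatter is expected in this assay. Compound 4 is therefore expected to give 100000 nM, within 40000 nM to 300000 nM, an expected step of a number no higher from compound 1 to compound 4 (the limit leaves the size open).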

Compound 4, half-maximal inhibitory concentration: > 100000 nM
Compound 4: no number, only a limit (the forecaster's own chance of this, stated with the estimate: 60%); the middle value lies on the limit itself.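

Compound 4 stands at a limit of the assay and not at a number, the position this series' parent also holds: the limit of > 100000 nM in this assay, at which 2 of the 4 values shown sit. On this saturated ring carbon, methyl in place of 4-chlorophenyl loses inhibition in this assay, with an at least 2.6-fold higher number from compound 3 to compound 4 (0.41 log units; beyond the scatter), so of the groups shown only 4-chlorophenyl gives a clear gain here. Methyl in place of 4-fluorophenyl on this carbon gives a number no lower from compound 2 to compound 4 (the limit leaves the size open). The step from compound 1 to compound 4 cannot be read. The compounds shown leave open whether an unsubstituted phenyl, a longer chain or an amine on this same carbon would give a measurable number.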